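Adding a Chloro Group to the Pyridyl Ether of Compound 1

The source may report more compounds than this note shows. Statements on the series, on what has been measured and on what is new or still open speak of the compounds shown alone.

Compound 1 `C[C@@]12C[C@@H]1CC(COc1cccnc1)N2` is one of two compounds tested in an assay on CHO-K1 cells for displacement of a labelled ligand from Neuronal acetylcholine receptor; alpha4/beta2 (Homo sapiens), read by scintillation counting (a lower number here means a stronger inhibitor, a higher number a weaker inhibitor), and in this assay compound 1 gives 3.6 nM. Compound 2 `c1ccc(OC[C@@H]2C[C@H]3C[C@H]3N2)nc1` reaches only a limit of the assay, > 10000 nM, which is a limit and not a number. That result is the limit of > 10000 nM in this assay, at which 1 of the 2 values shown sits, so the value of compound 1 is the only true number shown, and no step between measured compounds can be read off.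

Compound 3 `C[C@@]12C[C@@H]1CC(COc1ccc(Cl)nc1)N2` has not yet been tested. It differs from compound 1 in one place: chloro in place of hydrogen on an aromatic carbon. The chloro sits on an aromatic carbon of the six-membered aromatic ring with one nitrogen, next to the ring nitrogen.

Going by the values given here, no measured pair shows what this change does here, so the expectation rests on compound 1 alone. The expected step is a 2.0-fold lower number from compound 1 to compound 3 (0.30 log units; within the scatter), a small move toward a stronger binder or none beyond the scatter. For compound 3 the estimated result in this assay is 1.8 nM, with a range from 0.5 nM to 7 nM.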

Compound 3, inhibition constant: 6880 nM
For compound 3 the middle estimate is 3800-fold (3.58 log units) below the measured one; measured number outside the range, above it.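

In this assay, putting chloro in place of hydrogen on the aromatic carbon next to the ring nitrogen gives a 1900-fold higher number from compound 1 to compound 3 (3.28 log units; beyond the scatter), a large loss of binding from a change of only 1 heavy atom. Going by these compounds alone, compound 1 and compound 3 form the first measured pair that differs in one place, and they show that this position is far from free to change: a strong binder becomes a weak one with this single substitution. Compound 2 differs from both in more than one place and gives only a limit of the assay, so no step to it can be read, and nothing measured here bears on why the number rises so far.

As far as these compounds go, it remains open whether the loss belongs to chloro itself or would follow any group at this place, a question that fluoro, methyl or methoxy on the same carbon could answer. From the compounds shown here alone, it is also open whether chloro on another carbon of the six-membered aromatic ring with 1 nitrogen would cost as much.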